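Benzylidene series: whole-organism inhibition, moving to a catechol-type arene

The compounds below may be only part of what the source reports. "The series", "measured", "known", "first", "only" and "open" are said of these compounds alone.

Measured so far:
compound 1, `COc1ccc(/C=C2\C=C(c3ccc(Cl)cc3)OC2=O)cc1`: 4%
compound 2, `O=C1/C(=C/c2ccccc2)C=C(c2ccc(Cl)cc2)N1Cc1ccccc1`: 24%

Both numbers come from a functional assay on the whole organism (strain Wistar) for inhibition, with Rattus norvegicus as the target, with stated times of 30 min and 2 h, at a dose of 20 mg/kg by the oral route; a higher number here means more inhibition at the dose given (going by the name of the read-out), a lower number less inhibition. Of the two, compound 2 stands highest: in this assay compound 2 gives 24%, while compound 1 gives 4%, a gap beyond the usual scatter. Going by the values given here, compounds 1 and 2 differ in more than one place, so no single-change step connects them and their two values can only be read side by side.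

Compound 3, `COc1cc(/C=C2\C=C(c3ccc(Cl)cc3)N(Cc3ccccc3)C2=O)ccc1O`, has not been measured in this assay. It differs from compound 2 in one place: 4-hydroxy-3-methoxyphenyl in place of phenyl on a double-bonded chain carbon bound to a double-bonded ring carbon. Among the compounds with values here, nothing among the measured compounds isolates a change of this kind, so there is no measured step to lean on. With the shared core of compound 2 kept intact, the working expectation is a step from compound 2 to compound 3 of a number 1 percentage points higher from compound 2 to compound 3 (within the scatter) in this assay, that is, no change beyond the scatter in either direction. Compound 3 is therefore expected to give about 25% in this assay, with a plausible range from 10% to 45%.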

Compound 3, a percentage reported as inhibition, in the whole organism at one dose (the size of the read-out at that dose, not a potency): 36%
The estimate for compound 3 lay 11 percentage points below the measured number; the range from low to high includes it.
By their numbers in this assay, from the lowest: compound 1; then compound 2; then compound 3.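

In this assay, going by these compounds alone, 4-hydroxy-3-methoxyphenyl in place of phenyl gives a number 12 percentage points higher from compound 2 to compound 3 (beyond the scatter) and provides the only single-change reading so far. This position, on a double-bonded chain carbon bound to a double-bonded ring carbon, therefore accepts a larger aryl group carrying a hydrogen-bond donor and hydrogen-bond acceptors without loss of inhibition at the dose given, and the step is modest but clear of the usual scatter. No measurement available here bears on what lies behind this step.

The compounds shown do not separate the contribution of the hydroxy group from that of the methoxy group within 4-hydroxy-3-methoxyphenyl on the shared core of compound 2, nor do they show whether the same change would give a similar step on the core of compound 1. Also open, going by these compounds, is how an amine or a carboxylic acid on the aromatic ring at this position would compare with 4-hydroxy-3-methoxyphenyl on the shared core.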